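A few compounds are considered here, and "the series" means these few. Any claim that something is new, unique, unknown or untested is made for them only; others in the source may bear on it.

Measured compounds:
- Compound 1, `COc1cc(O)ccc1/C=C/C(=O)c1ccc(N)cc1`: "not determined" (no result reported) in an assay on isolated protein for inhibition of DNA topoisomerase 1 (Homo sapiens), tested at 20 uM; on this read-out higher numbers stand for a stronger effect at the one concentration tested and lower numbers for a weaker effect
- Compound 2, `O=C(/C=C/c1ccc(F)cc1)c1ccc(O)cc1O`: 56.7%
- Compound 3, `COc1ccc(/C=C/C(=O)c2ccc(O)cc2)cc1Br`: 6.6%

Three compounds of the same chalcone type are on record, but only two of them carry a number. Compound 1 gave no result, so nothing can be said of it beyond its structure. Compound 2 stands highest of the two numbers, with this assay returning 56.7% for it. The nearest entry is compound 3, whose 6.6% lies well below, a gap beyond the scatter of repeated runs. Within the data shown here, since compound 2 and compound 3 differ in more than one place, their two values show only that compound 2 is the stronger of the pair on this read-out.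

The unmeasured compound 4, `O=C(/C=C/c1ccc(N2CCCC2)cc1)c1ccc(O)cc1O`, keeps the whole of compound 2 except for one exchange: pyrrolidin-1-yl in place of fluoro on an aromatic carbon. Among the measured compounds shown here, no step between measured compounds carries this exchange, so its size and direction are open. Given that much larger group entering where a single fluorine left, a shift beyond the scatter in either direction is plausible; the estimate therefore leans only slightly below the parent. Compound 4 is expected to give about 45% in this assay, within 15% to 75%, an expected step of a number 11.7 percentage points lower from compound 2 to compound 4 (beyond the scatter).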

Compound 4, a percentage reported as inhibition, at one concentration (the size of the read-out at that concentration, not a potency): 64.4%
Compound 4: middle estimate off by 19.4 percentage points, on the low side, and the stated range covers the measured number.
By their numbers in this assay, from the lowest: compound 3; then compounds 2 and 4 (each within the scatter of the next).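

Among these compounds, the exchange of fluoro for pyrrolidin-1-yl on an aromatic carbon, para to a large group, gives a number 7.7 percentage points higher from compound 2 to compound 4 (within the scatter) in this assay and is the first change at this position that can be read on its own, since the earlier compounds differ from one another in more than one place. It shows that a group of five heavy atoms carrying a five-membered non-aromatic ring can stand where a single fluorine stood, with compound 4 and compound 2 reading alike on this measure. No measured finding at hand accounts for this close agreement between the two compounds.

From the compounds shown here alone, whether this tolerance extends to other groups at the same place stays open: an open-chain amine such as diethylamino, a six-membered ring such as morpholine, or a carboxylic acid could each read differently from compound 2. Going by these compounds, it is also open whether the same exchange would read alike on the core of compound 3, and so whether the result holds beyond this one pair.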